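A few compounds are considered here, and "the series" means these few. Any claim that something is new, unique, unknown or untested is made for them only; others in the source may bear on it.

Series notes. Compound 3 `Clc1ccc(Sc2c(-c3ccc(Cl)cc3)[nH]c3ccccc23)cc1` and compound 1 `Clc1ccc(Sc2c(-c3ccc(Cl)cc3)[nH]c3ccc(Cl)cc23)cc1` share one core; compound 2 `CCOC(=O)C1CCN(C(=S)Sc2c(-c3ccc(Br)cc3)[nH]c3ccccc23)CC1` carries a different core, and the difference between the two cores is not broken down here. Compound 4 `CCOC(=O)C1CCN(C(=S)Sc2c(-c3ccc(Br)cc3)[nH]c3ccc(Cl)cc23)CC1` is not yet measured. In a functional assay on B16-F10 cells (Mus musculus) for inhibition, read by MTT assay, with a stated time of 72 h (on this read-out lower numbers stand for stronger inhibition of growth and higher numbers for weaker inhibition of growth), compound 3 gives 28000 nM, compound 1 gives 28000 nM and compound 2 gives 27000 nM; the three numbers lie within the usual scatter of one another, so no order among them is drawn.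

The change from compound 3 to compound 1 is chloro in place of hydrogen on an aromatic carbon; the step it made, no change at the digits printed from compound 3 to compound 1 (within the scatter), is within the scatter. The same change, (chloro in place of hydrogen on an aromatic carbon), leads from compound 2 to compound 4, and it occurs twice among the compounds shown. Going by the values given here, only one measured instance exists, so the expectation for compound 4 rests on a single precedent and on compound 2 at 27000 nM.

In this assay compound 4 is expected at about 27000 nM. The expected lower end for compound 4 is 12000 nM and the expected upper end is 60000 nM. The expected step is no change at the digits printed from compound 2 to compound 4 (within the scatter), kept flat because no change at the digits printed from compound 3 to compound 1 (within the scatter) showed no movement for the same change.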

Compound 4, concentration for 50% growth inhibition: 21000 nM
Estimate against measurement, compound 4: 1.3-fold (0.11 log units) above; the range from low to high includes it.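

In this assay, chloro in place of hydrogen on an aromatic carbon, on a six-membered aromatic ring of carbon only that is part of a fused or bridged system of two rings, gives a 1.3-fold lower number from compound 2 to compound 4 (0.11 log units; within the scatter). Carried from one core to the other, the change behaves alike on both, and no difference between the cores can be drawn from it: the same change on two cores in this assay, no change at the digits printed (within the scatter) from compound 3 to compound 1 and a 1.3-fold lower number (0.11 log units; within the scatter) from compound 2 to compound 4, 1.3-fold (0.11 log units) apart, within the scatter of two such steps. Going by these compounds alone, this shows only that the change is without a readable effect on these two cores; it does not show that the same would hold on a third core, and with two pairs it gives no general rule for the series.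

The compounds shown leave open whether an amine, a carboxylic acid or a longer chain in place of the chloro would move the number beyond the scatter on either core. As far as these compounds go, the effect of the difference between the two cores also stays open, since compound 1 and compound 4 differ in more than one place.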